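Replacing the trimethylpiperazine on the shared core with ethylpiperazine

The source may hold more compounds than are shown below. What is called first, only, known or untested is meant among the compounds shown, and "the series" means these compounds.

Compound 3 `C[C@@H]1CN(c2cccc3c2C[C@H](CN(C)[C@H]2CCCc4cccnc42)NC3)C[C@H](C)N1C` carries a 3,4,5-trimethylpiperazin-1-yl group on the aromatic carbon of its shared core. In a functional assay on CCRF-CEM cells for agonist activity at C-X-C chemokine receptor type 4 (Homo sapiens), read by calcium flux, with a stated time of 25 min (a lower number here means that less compound is needed, a higher number that more compound is needed for the effect), compound 3 gives only a limit of the assay, > 30000 nM. Compound 1 `C[C@@H]1CN(c2cccc3c2C[C@H](CN(C)[C@H]2CCCc4cccnc42)NC3)C[C@H](C)N1` likewise gives only a limit, > 30000 nM. Compound 2 `CN(C[C@H]1Cc2c(cccc2N2CCN(Cc3ccccn3)CC2)CN1)[C@H]1CCCc2cccnc21` also gives only a limit, > 30000 nM. Within the data shown here, the one step between measured compounds, a step that the two limits leave unreadable from compound 1 to compound 3, is therefore not readable as a number, since both ends sit at the same limit, (the limit of > 30000 nM in this assay, at which 3 of the 3 values shown sit).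

Compound 4 `CCN1CCN(c2cccc3c2C[C@H](CN(C)[C@H]2CCCc4cccnc42)NC3)CC1` differs from compound 3 by the change (4-ethylpiperazin-1-yl in place of 3,4,5-trimethylpiperazin-1-yl on an aromatic carbon). The measured step from compound 1 to compound 3 bears on the same position but gives no size, and compound 2, with a differently substituted piperazine at that position, also remains at the limit. With every value shown sitting at the limit, the step that the limit leaves unreadable from compound 3 to compound 4 is expected to be small or nothing readable, and compound 4 is expected to give 40000 nM, with a range from 10000 nM to 100000 nM, most likely again reported only as a limit in this assay.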

Compound 4, half-maximal effective concentration: > 30000 nM
Compound 4 was reported as a limit (the forecaster's own chance of this, stated with the estimate: 85%); the middle value does not contradict the limit.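

In this assay compound 4 gives only a limit, > 30000 nM. The steps to compound 4 from compound 1, compound 2 and compound 3 cannot be read. The compounds shown leave open which group on the aromatic carbon of the shared core, if any, would give a number rather than a limit in this assay.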